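The compounds below may be only part of what the source reports. "The series", "measured", "known", "first", "only" and "open" are said of these compounds alone.

Compound 3, `Cc1cc(-c2ccc(C(F)(F)F)cc2)nn1S(=O)(=O)Oc1ccccc1`, gives 35.9% in a functional assay on the whole organism for inhibition, with Mus musculus as the target, with stated times of 3 days and 30 min, at a dose of 30 mg/kg by the oral route (on this read-out lower numbers stand for less inhibition and higher numbers for more inhibition at the one dose given (going by the name of the read-out)), the highest of the three numbers recorded. Compound 2, `Cc1ccc(-c2cc(C)n(S(=O)(=O)Oc3ccc(I)cc3)n2)cc1`, gives 27%, and compound 1, `Cc1ccc(-c2cc(C)n(S(=O)(=O)Oc3ccccc3)n2)cc1`, gives 15.2%. Compound 4, `CCc1ccc(-c2cc(C)n(S(=O)(=O)Oc3ccccc3)n2)cc1`, differs from compound 3 in one place: ethyl in place of trifluoromethyl on an aromatic carbon. Among the compounds with values here, no measured step swaps these two groups directly, but the change at the same place from methyl to trifluoromethyl gave a number 20.7 percentage points higher from compound 1 to compound 3 (beyond the scatter), while the iodo substitution gave a number 11.8 percentage points higher from compound 1 to compound 2 (beyond the scatter). Ethyl is expected to sit between methyl and trifluoromethyl in effect, so a modest drop, a number 12.9 percentage points lower from compound 3 to compound 4 (beyond the scatter), is expected. Compound 4 is therefore estimated at 23%, within a range from 9% to 37%.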

Compound 4, a percentage reported as inhibition, in the whole organism at one dose (the size of the read-out at that dose, not a potency): 21.1%
Compound 4: the middle estimate sits 1.9 percentage points above what was measured, and the stated range covers the measured number.
By their numbers in this assay, from the lowest: compounds 1, 4, 2 and 3 (each within the scatter of the next, the first and the last beyond it).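

In this assay, within the data shown here, the group on the aromatic carbon para to a large group matters when trifluoromethyl is exchanged: ethyl in its place gives a number 14.8 percentage points lower from compound 3 to compound 4 (beyond the scatter), the first direct comparison of these two groups. Extending methyl to ethyl at the same place gives a number 5.9 percentage points higher from compound 1 to compound 4 (within the scatter), so this added carbon does not separate compound 1 from compound 4. No available evidence explains these results.

The compounds shown leave open how a longer chain such as propyl, a methoxy group or a nitrile would read at this place.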